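Replacing the substituents on the aromatic ring of compound 3

The source may report more compounds than this note shows. Statements on the series, on what has been measured and on what is new or still open speak of the compounds shown alone.

- compound 1 `C/C(=N\NC(=O)c1cccc(S(=O)(=O)N2CCOCC2)c1)c1cccc(O)c1` gives > 100000 nM
- compound 2 `CCN(CC)c1ccc(/C=N/NC(=O)c2cccc(S(=O)(=O)N3CCOCC3)c2)c(O)c1` gives 730 nM
- compound 3 `COc1ccc(/C=N/NC(=O)c2cccc(S(=O)(=O)N3CCOCC3)c2)c(O)c1` gives 2790 nM

These compounds share a core and were tested in a functional assay on ECa-109 cells for antiproliferative activity against ECa-109 cell line (Homo sapiens), read by MTT assay, with a stated time of 72 h (on this read-out higher numbers stand for weaker inhibition and lower numbers for stronger inhibition), the measure used throughout this comparison. The entry for compound 1 is a limit of the assay and not a number. Of the two true numbers, compound 3 holds the higher, which means weaker inhibition. The gap between the pair is a 3.8-fold higher number from compound 2 to compound 3 (0.58 log units; beyond the scatter) and counts as modest.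

Compound 4 `O=C(N/N=C/c1cc(Br)cc(Br)c1O)c1cccc(S(=O)(=O)N2CCOCC2)c1` has not yet been measured. It differs from compound 3 in one part: 3,5-dibromo-2-hydroxyphenyl in place of 2-hydroxy-4-methoxyphenyl on a carbon with a double bond to nitrogen, with 3,5-dibromo-2-hydroxyphenyl in place of 2-hydroxy-4-methoxyphenyl on a carbon with a double bond to nitrogen.

Within the data shown here, only one measured step touches this part of the molecule, the modest 3.8-fold higher number from compound 2 to compound 3 (0.58 log units; beyond the scatter) in this assay. It involves different groups and no bromine, so it is only a rough guide to size and says little about direction. A modest step is therefore expected, leaning slightly towards stronger inhibition, and no real change remains possible. The estimated step is a 1.9-fold lower number from compound 3 to compound 4 (0.27 log units; within the scatter) in this assay, and its direction is uncertain. For compound 4 the expected value is 1500 nM, with an estimated range from 400 nM to 6000 nM in this assay.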

Compound 4, half-maximal inhibitory concentration: 10300 nM
For compound 4 the middle estimate is 6.9-fold (0.84 log units) below the measured one; the measured number lies above the stated range.
By their numbers in this assay, from the lowest: compound 2; then compound 3; then compound 4. At a limit, above all of these: compound 1.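

In this assay, putting 3,5-dibromo-2-hydroxyphenyl in place of 2-hydroxy-4-methoxyphenyl on the carbon with a double bond to nitrogen gives a 3.7-fold higher number from compound 3 to compound 4 (0.57 log units; beyond the scatter), which means weaker inhibition. Among these compounds, both groups hold the same number of heavy atoms and one hydrogen-bond donor, so the number moved although those counts stayed the same, and this change brings in bromine, which the earlier compounds did not carry. Together with the earlier step, a 3.8-fold higher number from compound 2 to compound 3 (0.58 log units; beyond the scatter), this shows that the activity responds to what is on this aromatic ring, but nothing available here explains why the two bromine atoms give weaker inhibition.

The compounds shown do not separate the loss of the methoxy group from the arrival of the two bromine atoms, so a ring with a single bromine or with two chlorine atoms would be needed to tell which one matters. They also leave open whether another amine on the ring, such as a pyrrolidine or a dimethylamino group, would match or improve on the diethylamino group of compound 2, which gives 730 nM.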